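From ethoxycarbonyl to 4-chlorophenyl on the shared core

The source may hold more compounds than are shown below. What is called first, only, known or untested is meant among the compounds shown, and "the series" means these compounds.

Compound 1 `C=C[C@@](C)(/C=C/c1ccc(O)cc1)CCC1OC1(C)C` and compound 2 `C=C[C@@](C)(/C=C/c1ccc(O)c(/C=C/C(=O)OCC)c1)CCC=C(C)C` have both been tested in a functional assay on Jurkat cells (Homo sapiens) for cytotoxicity, with a stated time of 72 h; on this read-out lower numbers stand for an effect already at smaller amounts and higher numbers for an effect only at larger amounts of compound. Compound 1 gives only a limit, > 49000 nM. Compound 2 also gives only a limit, > 49000 nM, so no number fixes its place on the scale. The picture so far is a single ceiling: the limit of > 49000 nM in this assay, at which 2 of the 2 values shown sit. No measured step in one place connects any of these compounds.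

Compound 3 `C=C[C@@](C)(/C=C/c1ccc(O)c(/C=C/c2ccc(Cl)cc2)c1)CCC=C(C)C` keeps the core of compound 2 but carries 4-chlorophenyl in place of ethoxycarbonyl on a double-bonded chain carbon bound to a double-bonded chain carbon. Within the data shown here, with no measured step as a guide, the expectation in this assay is a small move towards smaller amounts, possibly none beyond the usual scatter, and another limit would be no surprise. The estimated change is an at least 1.6-fold lower number from compound 2 to compound 3 (0.21 log units; that floor lies within the scatter). For compound 3 the expected value is 30000 nM, with an estimated range from 10000 nM to 60000 nM.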

Compound 3, half-maximal effective concentration: > 49000 nM
Compound 3: no number, only a limit; the forecaster's own chance of this, stated with the estimate: 55%; middle value at least 1.6-fold (0.21 log units) from the limit.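

In this assay compound 3 gives only a limit, > 49000 nM. Compound 2 also gives only a limit, and the step between compound 2 and compound 3, 4-chlorophenyl in place of ethoxycarbonyl, cannot be read. The compounds shown leave open where any of them falls on the scale, and all three share one result: the limit of > 49000 nM in this assay, at which 3 of the 3 values shown sit.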